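The source may hold more compounds than are shown below. What is called first, only, known or untested is meant among the compounds shown, and "the series" means these compounds.

Measured so far in a functional assay on CAKI-1 cells (Homo sapiens) for cytotoxicity, read by sulforhodamine B assay, with a stated time of 48 h, tested at 0.01 uM; on this read-out higher numbers stand for a weaker effect at the one concentration tested and lower numbers for a stronger effect:

Compound 1, `COc1cc(C)cc(-c2c(-c3ccnc(-c4ccc(C(C)=O)cc4)c3)cnn2CC#N)c1`: 97%
Compound 2, `COc1cc(C)cc(-c2nn(CC#N)cc2-c2ccc(-c3cccc(C(C)=O)c3)nc2)c1`: 96%
Compound 3, `COc1cc(C)cc(-c2nn(CC#N)cc2-c2ccnc(-c3ccc(N(C)C)cc3)c2)c1`: 92%

Compound 1 gives the highest of the three numbers in this assay, but the gap to compound 2 and to compound 3 lies within the usual scatter, so no order among the three can be read. All three compounds leave most cells intact at the single concentration tested. For the measured compounds named here, no pair of measured compounds differs in only one place, so no step is known.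

Compound 4, `COc1cc(C)cc(-c2c(-c3ccnc(-c4ccc(N(C)C)cc4)c3)cnn2CC#N)c1`, has not been measured. It differs from compound 1 as follows: dimethylamino in place of acetyl on an aromatic carbon. With every measured number sitting within the scatter of every other, nothing in the series points to a change beyond the scatter for this assay; the step is expected to be small and of no settled direction. The estimate for compound 4 is 93%, with a range from 84% to 101%, which means an expected step of a number 4 percentage points lower from compound 1 to compound 4 (within the scatter) from the value of compound 1.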

Compound 4, a percentage reported as activity, at one concentration (the size of the read-out at that concentration, not a potency): -6%
Beside the measured number, compound 4's estimate is 99 percentage points above it; measured number below the stated range.
By their numbers in this assay, from the lowest: compound 4; then compounds 3, 2 and 1 (each within the scatter of the next).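

In this assay, for the compounds shown here, replacing acetyl with dimethylamino on the aromatic carbon gives a number 103 percentage points lower from compound 1 to compound 4 (beyond the scatter), the first step to lie beyond the scatter. This shows that the read-out can respond strongly to the group at this position, para to a large group, even though the leaving and entering groups have the same counts of heavy atoms, hydrogen-bond donors and hydrogen-bond acceptors. Nothing measured here accounts for the size of this step.

From the compounds shown here alone, the result rests on a single pair, so it remains open whether the step is specific to dimethylamino or would also appear with a primary amine, a morpholine or a methoxy group on the same carbon. A carboxylic acid at this position would test whether the weak effect seen with acetyl extends to another carbonyl group.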